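Swapping a Methoxyphenyl for a Pyridazinyl Amide

The source may report more compounds than this note shows. Statements on the series, on what has been measured and on what is new or still open speak of the compounds shown alone.

Measured so far, in an assay on CHO cells for positive allosteric modulation of metabotropic glutamate receptor 5 (Homo sapiens), read by FLIPR; a lower number here means that less compound is needed, a higher number that more compound is needed for the effect:
Compound 1, `O=C(Nc1ccc(Cl)cc1CN1C(=O)c2ccccc2C1=O)c1ncccn1`, gives 2100 nM.
Compound 2, `COc1ccccc1C(=O)Nc1ccc(Cl)cc1CN1C(=O)c2ccccc2C1=O`, gives > 100000 nM.

Compound 2 sits at the limit of > 100000 nM in this assay, at which 1 of the 2 values shown sits, so its reading is a limit of the method and not a measured number. Compound 3, `O=C(Nc1ccc(Cl)cc1CN1C(=O)c2ccccc2C1=O)c1cccnn1`, differs from compound 2 by pyridazin-3-yl in place of 2-methoxyphenyl on a carbonyl carbon. Among the compounds with values here, only one measured step bears on this change, and it runs the other way: an at least 47-fold higher number from compound 1 to compound 2 (1.67 log units; beyond the scatter). In that step a six-membered ring with two nitrogens gave way to the methoxyphenyl and the number climbed beyond what could be read. Compound 3 brings back a six-membered ring with two nitrogens, closely resembling the arrangement in compound 1, so a large fall in the number is expected, about an at least 25-fold lower number from compound 2 to compound 3 (1.39 log units; beyond the scatter) in this assay. The exact size cannot be pinned down, since compound 2 has only a limit. Compound 3 is expected at 4000 nM, within a range from 1200 nM to 20000 nM.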

Compound 3, half-maximal effective concentration: > 100000 nM
Compound 3 gave a limit, no number; the forecaster's own chance of this, stated with the estimate: 15%; at least 25-fold (1.39 log units) between middle value and limit.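

Having a six-membered aromatic ring with two nitrogens on the carbonyl carbon is not enough in itself: with pyridazin-3-yl in place of pyrimidin-2-yl, there is an at least 47-fold higher number from compound 1 to compound 3 (1.67 log units; beyond the scatter). In this assay, this position therefore separates two rings of the same size that carry the same number of nitrogens, and only pyrimidin-2-yl gives a readable value among the groups shown. The step from compound 2 to compound 3 cannot be read, since both of its ends are limits and not numbers: the limit of > 100000 nM in this assay, at which 2 of the 3 values shown sit.

From the compounds shown here alone, how far beyond the limit compound 2 and compound 3 really lie stays unknown, so 2-methoxyphenyl and pyridazin-3-yl cannot be ranked against each other. Going by these compounds, whether a plain phenyl, or a pyrimidin-2-yl carrying an amine, would give a readable value also remains open.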